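Chalcone-flavone hybrids: aryl swap at four-carbon linker

This account rests on a few compounds, and the source may have more. Where it says the series, first, only, none or still open, it means among the compounds named here.

Measured so far:
- compound 1, `COc1cc(OC)c2c(=O)c(OCCCOc3ccccc3/C=C/C(=O)/C=C/c3cccc([N+](=O)[O-])c3)c(-c3cc(OC)c(OC)c(OC)c3)oc2c1`, giving 5400 nM in a functional assay on SGC-7901 cells (Homo sapiens) for antiproliferative activity, read by MTT assay, with a stated time of 48 h; a higher number here means a weaker inhibitor, a lower number a stronger inhibitor
- compound 2, `COc1cc(OC)c2c(=O)c(OCCCCOc3ccccc3/C=C/C(=O)/C=C/c3ccc(Cl)cc3)c(-c3cc(OC)c(OC)c(OC)c3)oc2c1`, giving 9150 nM in this assay

Both measured compounds share the same core and differ in the linker length and in the aryl group at the end of the dienone chain. For the measured compounds named here, compound 2 and compound 1 give numbers that sit within the usual scatter of each other, so the two cannot be separated on the present data; no step between them is computed here.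

Compound 3, `COc1cc(OC)c2c(=O)c(OCCCCOc3ccccc3/C=C/C(=O)/C=C/c3cccc([N+](=O)[O-])c3)c(-c3cc(OC)c(OC)c(OC)c3)oc2c1`, keeps the four-carbon linker of compound 2 and differs from it only in the terminal aryl group: 3-nitrophenyl in place of 4-chlorophenyl on a double-bonded chain carbon bound to a double-bonded chain carbon. The same 3-nitrophenyl is carried by compound 1, which gives 5400 nM with a shorter linker. On that basis the step from compound 2 is expected to be small, at most a drift toward a lower number and not clearly beyond the scatter. The expected step is a 1.4-fold lower number from compound 2 to compound 3 (0.15 log units; within the scatter). For compound 3 the estimate is 6500 nM, with a range from 3000 nM to 14000 nM.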

Compound 3, half-maximal inhibitory concentration: 4030 nM
For compound 3 the middle estimate is 1.6-fold (0.21 log units) above the measured one; low and high end bracket the measured number.
By their numbers in this assay, from the lowest: compounds 3, 1 and 2 (each within the scatter of the next, the first and the last beyond it).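

For the compounds shown here, at the position on a double-bonded chain carbon bound to a double-bonded chain carbon, the terminal aryl group now shows a readable effect: in this assay 3-nitrophenyl in place of 4-chlorophenyl gives a 2.3-fold lower number from compound 2 to compound 3 (0.36 log units; beyond the scatter) on the four-carbon linker, a modest step but the only one so far that can be read beyond the scatter. With 3-nitrophenyl held constant, compound 1 gives 5400 nM on its shorter linker and compound 3 gives 4030 nM on the four-carbon linker, and these two values sit within the scatter of each other, so linker length has no separable effect on these data. Nothing on hand explains the aryl step, which rests on a single pair of compounds.

From the compounds shown here alone, whether the step belongs to the nitro group, to the loss of the chlorine or to the whole aryl swap stays open, as does whether it would hold on the shorter linker. Also open, going by these compounds, is how the terminal position would respond to an amine or a carboxylic acid on the phenyl ring, and how the series would respond to a longer chain in the linker.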